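The source may hold more compounds than are shown below. What is called first, only, known or untested is meant among the compounds shown, and "the series" means these compounds.

Measured in a functional assay on K562 cells (Homo sapiens) for inhibition, read by trypan blue exclusion, with a stated time of 24 h, tested at 10 uM; a lower number here means less inhibition of growth, a higher number more inhibition of growth at the concentration tested:
- compound 1 `NC(=O)c1cc(Cl)ccc1NC(=O)COc1ccccc1`: 87%
- compound 2 `Cc1ccccc1OCC(=O)Nc1ccc(Cl)cc1C(N)=O`: 75.9%

Of these two, compound 2 stands lower at 75.9%. Compound 3 `COc1ccc(NC(=O)COc2ccccc2C)c(C(N)=O)c1` differs from compound 2 by one change: methoxy in place of chloro on an aromatic carbon. For the measured compounds named here, the only measured step is a number 11.1 percentage points lower from compound 1 to compound 2 (beyond the scatter). Going by the values given here, that step concerns a different change at another place, so it offers only a rough guide to size, and no measured step covers this exchange. A modest fall in this assay is expected, with the estimated step being a number 9.9 percentage points lower from compound 2 to compound 3 (within the scatter). For compound 3 the estimated value is 66%. The expected range runs from 46% to 83%.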

Compound 3, percent growth inhibition at one concentration: 40.1%
Beside the measured number, compound 3's estimate is 25.9 percentage points above it, and the stated range ends above it.
By their numbers in this assay, from the lowest: compound 3; then compound 2; then compound 1.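

Exchanging chloro for methoxy on this aromatic carbon, meta to a carbamoyl group and para to a large group, brings a number 35.8 percentage points lower from compound 2 to compound 3 (beyond the scatter) in this assay. Growth inhibition therefore depends strongly on the group at this position, and this step is larger than the methyl change at another place, which gave a number 11.1 percentage points lower from compound 1 to compound 2 (beyond the scatter). Nothing available accounts for the fall.

As far as these compounds go, it remains open whether the loss is specific to methoxy or extends to other replacements for chloro. A fluorine atom, an amine or a longer alkoxy chain at this position could separate these possibilities.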